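The compounds below may be only part of what the source reports. "The series", "measured", "known", "first", "only" and "open" are said of these compounds alone.

Three compounds have been measured in an assay on ileum for inhibition of Voltage-dependent L-type calcium channel subunit alpha-1C (Cavia porcellus); on this read-out lower numbers stand for stronger inhibition and higher numbers for weaker inhibition:

Compound 1, `CCOC(=O)C1=C(C)NC(C)=C(C(=O)OC)C1c1[nH]c(CC)nc1Cl`, gives 2.02 nM.
Compound 2, `CCOC(=O)C1=C(C)NC(C)=C(C(=O)OCC)C1c1[nH]c(CC)nc1Cl`, gives 0.158 nM.
Compound 3, `CCOC(=O)C1=C(C)NC(C)=C(C(=O)OC(C)(C)C)C1c1[nH]c(CC)nc1Cl`, gives 99.8 nM.

Among these three, compound 3 stands at the highest number, that is the weakest inhibition, and the steps to it are all large: a 49-fold higher number from compound 1 to compound 3 (1.69 log units; beyond the scatter) and a 630-fold higher number from compound 2 to compound 3 (2.80 log units; beyond the scatter). Compound 4, `CCOC(=O)C1=C(C)NC(C)=C(C(=O)OCc2ccccc2)C1c1[nH]c(CC)nc1Cl`, keeps the shared core and changes only the ester group: benzyl in place of tert-butyl on an oxygen next to a carbonyl group. For the measured compounds named here, no measured step covers a benzyl group, so the expectation rests on what the ester series shows. The step of a 13-fold lower number from compound 1 to compound 2 (1.11 log units; beyond the scatter) and the two steps to compound 3 together show that small straight groups on this oxygen give low numbers, while the tert-butyl group gives a much higher one. Since compound 4 leaves the tert-butyl group behind, it is expected to move back toward the range of compounds 1 and 2, giving an estimated 1 nM (range 0.1 nM to 10 nM), an expected step of a 100-fold lower number from compound 3 to compound 4 (2.00 log units; beyond the scatter).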

Compound 4, half-maximal inhibitory concentration: 2.66 nM
The estimate for compound 4 lay 2.7-fold (0.42 log units) below the measured number; the measured number falls inside the stated range.
By their numbers in this assay, from the lowest: compound 2; then compounds 1 and 4 (each within the scatter of the next); then compound 3.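

In this assay the benzyl group, with 7 heavy atoms against 4 for tert-butyl and a six-membered aromatic ring, does not carry the high number of compound 3 (the change gives a 38-fold lower number from compound 3 to compound 4 (1.57 log units; beyond the scatter)), so heavy-atom count alone does not set the number among these esters. Adding phenyl to the saturated chain carbon of the methyl ester leaves the number where it was (the step is a 1.3-fold higher number from compound 1 to compound 4 (0.12 log units; within the scatter)). Phenyl does not match methyl on that same carbon (the step is a 17-fold higher number from compound 2 to compound 4 (1.23 log units; beyond the scatter)), so in this set the ethyl ester alone reaches the lowest number.

On these data alone, whether a longer chain such as propyl or butyl, or a branched isopropyl group, follows ethyl or tert-butyl stays open. So does the effect of a methoxy group on the benzyl ring. No measurement here accounts for these differences.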